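A Smaller Sulfur-Bearing Group Replaces the Butylcarbamoyl Arm

The source may hold more compounds than are shown below. What is called first, only, known or untested is meant among the compounds shown, and "the series" means these compounds.

Three compounds sharing one core have been measured in an assay on DDT1 cells (Cricetulus griseus) for binding affinity to adenosine receptor A1 (Homo sapiens), read by radioligand binding; a lower number here means a stronger inhibitor, a higher number a weaker inhibitor:

Compound 1, `CCCCNC(=O)OC[C@H]1OC(n2cnc3c(NC4CCOC4)ncnc32)[C@H](O)[C@@H]1O`, gives 1410 nM.
Compound 2, `O=C(NC1CCC1)OC[C@H]1OC(n2cnc3c(NC4CCOC4)ncnc32)[C@H](O)[C@@H]1O`, gives 306 nM.
Compound 3, `O[C@@H]1[C@@H](CO/C(S)=N/C2CCCCC2)OC(n2cnc3c(NC4CCOC4)ncnc32)[C@@H]1O`, gives 253 nM.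

Compound 1 stands highest of the three numbers in this assay. Its nearest neighbour is compound 2, reached by a 4.6-fold lower number from compound 1 to compound 2 (0.66 log units; beyond the scatter), and its furthest is compound 3, reached by a 5.6-fold lower number from compound 1 to compound 3 (0.75 log units; beyond the scatter); both of these steps lie beyond the scatter. Between compound 2 and compound 3 the change is a 1.2-fold lower number from compound 2 to compound 3 (0.08 log units; within the scatter), within the scatter.

Compound 4, `CN(C)C(=S)OC[C@H]1OC(n2cnc3c(NC4CCOC4)ncnc32)[C@H](O)[C@@H]1O`, has not yet been measured. It differs from compound 1 in one place: a group of 5 heavy atoms (3 carbon, 1 nitrogen, 1 sulfur; no ring) in place of a group of 7 heavy atoms (5 carbon, 1 nitrogen, 1 oxygen; no ring), on an oxygen on a saturated carbon. The two measured steps that bear on this are the ones leaving compound 1, since each of them also replaces the butylcarbamoyl group on that oxygen, and each lowered the number modestly. Neither, however, shrinks the group or removes the hydrogen-bond donor as compound 4 does, so the expected step is smaller and less certain. For compound 4 the estimated step is a 1.8-fold lower number from compound 1 to compound 4 (0.25 log units; within the scatter). Compound 4 is therefore expected to give about 800 nM in this assay, within a range of 250 nM to 2500 nM.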

Compound 4, inhibition constant: 205 nM
Estimate against measurement, compound 4: 3.9-fold (0.59 log units) above; the measured number lies below the stated range.
By their numbers in this assay, from the lowest: compounds 4, 3 and 2 (each within the scatter of the next); then compound 1.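

In this assay, leaving the butylcarbamoyl group on this oxygen does not depend on adding a ring or a larger group: the ringless entering group of compound 4, with 5 heavy atoms, sulfur in place of oxygen and 0 hydrogen-bond donors against the 1 of butylcarbamoyl, gives a 6.9-fold lower number from compound 1 to compound 4 (0.84 log units; beyond the scatter). The remaining steps, a 1.2-fold lower number from compound 3 to compound 4 (0.09 log units; within the scatter) and a 1.5-fold lower number from compound 2 to compound 4 (0.17 log units; within the scatter), show that compound 4 cannot be separated from the two ring-bearing compounds, so among these four only butylcarbamoyl stands apart at this place. No measurement shown accounts for this result.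

Compound 4 alters the sulfur, the hydrogen-bond donor count and the size of the group in one step, so the compounds shown leave open which of these changes goes with the lower number. Dimethylcarbamoyl, with a carbonyl oxygen in place of the sulfur, and butylthiocarbamoyl, with sulfur in place of that carbonyl oxygen on the butyl chain, would each differ from the compounds here in one place and would help to separate these changes.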